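The source may report more compounds than this note shows. Statements on the series, on what has been measured and on what is new or still open speak of the compounds shown alone.

Of the compounds shown here, two that share one core have been measured in an ADME assay for permeability, using PAMPA, with a stated time of 4 h; on this read-out lower numbers stand for lower permeability and higher numbers for higher permeability. Compound 1 `Cn1c(COc2cccc(C(=O)O)c2)nc2ccc(Oc3ccccn3)cc21` gives 2.2 10^-6 cm/s in this assay. Compound 2 `Cc1ccc(Oc2ccc3nc(COc4cccc(C(=O)O)c4)n(C)c3c2)nc1` carries a methyl where compound 1 carries a hydrogen on an aromatic carbon; in this assay compound 2 gives 4.8 10^-6 cm/s. Within the data shown here, on these two numbers compound 2 stands highest; its only neighbour is compound 1, and the single measured step between them is a 2.2-fold higher number from compound 1 to compound 2 (0.34 log units; beyond the scatter), a modest rise.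

Compound 3 `Cn1c(COc2cccc(C(=O)O)c2)nc2ccc(Oc3ccc(F)cn3)cc21` has not yet been measured. Relative to compound 2 the change is fluoro in place of methyl on an aromatic carbon, so the same carbon that gained the methyl now holds a fluorine instead. Among the measured compounds shown here, only one measured step bears on this position, the one in which the methyl entered, and it was modest in size. Removing the methyl again and putting a fluorine in its place is therefore expected to move the number little, most likely back toward compound 1 or not at all beyond the scatter. Compound 3 is estimated at 3.5 10^-6 cm/s in this assay, with a range from 1.8 10^-6 cm/s to 6.5 10^-6 cm/s. The step this estimate implies, a 1.4-fold lower number from compound 2 to compound 3 (0.14 log units; within the scatter), is expected to be small.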

Compound 3, apparent permeability: 4.7 10^-6 cm/s
Beside the measured number, compound 3's estimate is 1.3-fold (0.13 log units) below it, and the stated range covers the measured number.
By their numbers in this assay, from the lowest: compound 1; then compounds 3 and 2 (each within the scatter of the next).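

In this assay, fluoro in place of methyl on this aromatic carbon gives a 1.0-fold lower number from compound 2 to compound 3 (0.01 log units; within the scatter) and so leaves the number where it was. Set against hydrogen, fluoro gives a 2.1-fold higher number from compound 1 to compound 3 (0.33 log units; beyond the scatter) and methyl gives a 2.2-fold higher number from compound 1 to compound 2 (0.34 log units; beyond the scatter) so the modest rise over compound 1 is no longer tied to methyl alone: two different groups of one heavy atom each, a carbon and a fluorine, both stand beyond the scatter from hydrogen on this carbon. No supporting data are available to say why these two groups read alike.

On these data alone, with only hydrogen, methyl and fluoro at this place, it remains open whether the rise continues, levels off or reverses with a larger group such as methoxy, trifluoromethyl or a longer alkyl chain, or with a nitrogen-bearing group such as an amine or a nitrile. As far as these compounds go, it also remains open whether methyl and fluoro would still read alike if the carboxylic acid of the shared core were replaced by an amide.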